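This account rests on a few compounds, and the source may have more. Where it says the series, first, only, none or still open, it means among the compounds named here.

Measured compounds:
compound 1 `FC(F)(F)c1cccc(/C=C\c2cc3ccccc3nc2Cl)c1` — 3700 nM
compound 2 `FC(F)(F)c1cc(/C=C\c2cc3ccccc3nc2Cl)cc(C(F)(F)F)c1` — 10500 nM
compound 3 `COc1ccc2nc(Cl)c(/C=C\c3ccc(C(F)(F)F)cc3C(F)(F)F)cc2c1` — > 50000 nM

In a functional assay on MDA-MB-468 cells (Homo sapiens) for antiproliferative activity, read by sulforhodamine B assay, with a stated time of 72 h (on this read-out lower numbers stand for stronger inhibition and higher numbers for weaker inhibition), compound 2 gives 10500 nM. Compound 1 differs from it by hydrogen in place of trifluoromethyl on an aromatic carbon, and this change gave a 2.8-fold lower number from compound 2 to compound 1 (0.45 log units; beyond the scatter). For compound 3 only a limit is reported in this assay, > 50000 nM; (the limit of > 50000 nM in this assay, at which 1 of the 3 values shown sits). How the core of compound 3 differs from the core of compound 2 is not broken down here.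

Compound 4 `COc1ccc2nc(Cl)c(/C=C\c3ccccc3C(F)(F)F)cc2c1` has not yet been measured. It differs from compound 3 by hydrogen in place of trifluoromethyl on an aromatic carbon. This is the same kind of change as that from compound 2 to compound 1, though the position differs: here the site is para to a large group, whereas in the earlier pair it is meta to a large group. Resting on a 2.8-fold lower number from compound 2 to compound 1 (0.45 log units; beyond the scatter) and on the limit of compound 3, compound 4 is expected to give an at least 2.0-fold lower number from compound 3 to compound 4 (0.30 log units; that floor lies within the scatter) in this assay. The estimate for compound 4 is therefore 25000 nM, in a range from 8000 nM to 60000 nM, with a real chance that only a limit is again reported.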

Compound 4, half-maximal inhibitory concentration: 4980 nM
The estimate for compound 4 lay 5.0-fold (0.70 log units) above the measured number; the measured number lies below the stated range.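

In this assay, hydrogen in place of trifluoromethyl on an aromatic carbon gave an at least 10-fold lower number from compound 3 to compound 4 (1.00 log units; beyond the scatter). Both steps with this change run in the same direction, but their size did not carry over from one core to the other: the same change on two cores in this assay, a 2.8-fold lower number (0.45 log units; beyond the scatter) from compound 2 to compound 1 and an at least 10-fold lower number (1.00 log units; beyond the scatter) from compound 3 to compound 4, at least 3.5-fold (0.54 log units) apart, beyond the scatter of two such steps

Compound 3 stands only as a limit, so the true size of its step stays unknown, and the core and the site of the change differ together between the two pairs, so these data cannot separate them: the limit of > 50000 nM in this assay, at which 1 of the 4 values shown sits.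

The compounds shown leave open what the methoxy group contributes on its own. They also leave open how a nitrile, an amine or a carboxylic acid in place of the remaining trifluoromethyl would read in this assay.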